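The compounds below may be only part of what the source reports. "The series", "measured", "known", "first", "only" and "open" are said of these compounds alone.

Within the data shown here, in a functional assay on HL-60 cells (Homo sapiens) for cytotoxicity, read by MTT assay, with a stated time of 48 h (on this read-out higher numbers stand for weaker inhibition and lower numbers for stronger inhibition), compound 2 `C=CC(=C)CC[C@@H]1[C@@]2(C)CCC[C@](C)(COC(=O)/C=C/c3ccc(O)cc3)[C@@H]2CC[C@@]1(C)O` gives 11800 nM, the lower of the two numbers so far, though compound 1 `C=CC(=C)CC[C@@H]1[C@@]2(C)CCC[C@](C)(COC(=O)/C=C\c3ccc(O)cc3)[C@@H]2CC[C@@]1(C)O`, which gives 14100 nM in this assay, stands within the scatter of it: a 1.2-fold lower number from compound 1 to compound 2 (0.08 log units; within the scatter). Compound 3 `C=CC(=C)CC[C@@H]1[C@@]2(C)CCC[C@](C)(COC(=O)/C=C/c3ccc(O)c(OC)c3)[C@@H]2CC[C@@]1(C)O` differs from compound 2 by methoxy in place of hydrogen on an aromatic carbon. Among the measured compounds shown here, the only measured step, the change in double-bond geometry from compound 1 to compound 2, does not touch the aromatic ring and gives no guide to a methoxy in place of hydrogen. For the measured compounds named here, with no step that bears on it, no move beyond the scatter is expected, and compound 3 is estimated at 10000 nM (range 4000 nM to 25000 nM), a step of a 1.2-fold lower number from compound 2 to compound 3 (0.07 log units; within the scatter).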

Compound 3, half-maximal inhibitory concentration: 14300 nM
Beside the measured number, compound 3's estimate is 1.4-fold (0.16 log units) below it, within the range that was stated.
By their numbers in this assay, from the lowest: compounds 2, 1 and 3 (each within the scatter of the next).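

In this assay, methoxy in place of hydrogen on an aromatic carbon, ortho to a hydroxy group, is the one change shown on the ring itself, and it stays within the scatter (a 1.2-fold higher number from compound 2 to compound 3 (0.08 log units; within the scatter)). The 2-(4-hydroxy-3-methoxyphenyl)ethenyl group also stays within the scatter when set against the other double-bond geometry (a 1.0-fold higher number from compound 1 to compound 3 (0.01 log units; within the scatter)). Nothing on record bears on this result. Still open, from the compounds shown here alone, is whether ethoxy at this position, or an amine or a carboxylic acid in place of the hydroxy group, would move the number beyond the scatter.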